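From 4-chlorophenyl to 3,4-dihydroxyphenyl

A few compounds are considered here, and "the series" means these few. Any claim that something is new, unique, unknown or untested is made for them only; others in the source may bear on it.

- Compound 1 `O=C(CCCc1nc2ccccc2c(=O)[nH]1)N/N=C/c1cc(O)c(O)c(O)c1` gives 78000000 nM
- Compound 2 `O=C(CCCc1nc2ccccc2c(=O)[nH]1)N/N=C/c1ccc([N+](=O)[O-])cc1` gives 316000000 nM
- Compound 3 `O=C(CCCc1nc2ccccc2c(=O)[nH]1)N/N=C/c1ccc(Cl)cc1` gives 353000000 nM

These values come from a physicochemical assay, read by spectrophotometry, with a stated time of 30 min; a lower number here means a stronger inhibitor, a higher number a weaker inhibitor. Compound 3 sits at the weak end of this small set, level with its nearest neighbour: the step is a 1.1-fold higher number from compound 2 to compound 3 (0.05 log units; within the scatter).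

Compound 4 `O=C(CCCc1nc2ccccc2c(=O)[nH]1)N/N=C/c1ccc(O)c(O)c1` has 3,4-dihydroxyphenyl in place of 4-chlorophenyl on a carbon with a double bond to nitrogen.

The closest measured group is the 3,4,5-trihydroxyphenyl of compound 1. Leaving it gave a 4.5-fold higher number from compound 1 to compound 3 (0.66 log units; beyond the scatter) and a 4.1-fold higher number from compound 1 to compound 2 (0.61 log units; beyond the scatter). Read backwards, these steps point to a lower number in this assay. A similar but slightly smaller change is expected: a 2.9-fold lower number from compound 3 to compound 4 (0.47 log units; beyond the scatter). Compound 4 is estimated at 120000000 nM, with an expected range of 50000000 nM to 290000000 nM.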

Compound 4, half-maximal inhibitory concentration: 95000000 nM
Compound 4: middle estimate off by 1.3-fold (0.10 log units), on the high side; measured number inside the range.
By their numbers in this assay, from the lowest: compounds 1 and 4 (each within the scatter of the next); then compounds 2 and 3 (each within the scatter of the next).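

In this assay, 3,4-dihydroxyphenyl at this position gives a clear drop from both groups without hydroxy, with a 3.7-fold lower number from compound 3 to compound 4 (0.57 log units; beyond the scatter) and a 3.3-fold lower number from compound 2 to compound 4 (0.52 log units; beyond the scatter). Hydrogen in place of the third hydroxy leaves the number level, with a 1.2-fold higher number from compound 1 to compound 4 (0.09 log units; within the scatter), so 3,4-dihydroxyphenyl and 3,4,5-trihydroxyphenyl cannot be told apart here. No measurement at hand accounts for these steps.

The compounds shown leave open whether a phenyl ring carrying a single hydroxy would match these two. They also leave open whether methoxy or an amine in place of hydroxy would keep the lower number.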